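Replacing the aryl group on a shared core: half-life in mice

The source may hold more compounds than are shown below. What is called first, only, known or untested is meant among the compounds shown, and "the series" means these compounds.

The measured compounds and their values in an ADME assay on the whole organism (Mus musculus, strain BALB/c) for metabolic stability, read by HPLC, with a stated time of 24 h, at a dose of 2.5 mg/kg by the intravenous route; a lower number here means that the compound disappears faster, a higher number that the compound lasts longer:
Compound 1 `CC(c1cc(F)c(F)c(F)c1)N1CC2(CCN(c3nc(=O)c4cc(C(F)(F)F)cc([N+](=O)[O-])c4s3)CC2)C1` gives 1.86 h.
Compound 2 `CC(c1ccc(OC(F)(F)F)cc1)N1CC2(CCN(c3nc(=O)c4cc(C(F)(F)F)cc([N+](=O)[O-])c4s3)CC2)C1` gives 8.51 h.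
Compound 3 `O=c1nc(N2CCN(CC3CCCCC3)CC2)sc2c([N+](=O)[O-])cc(C(F)(F)F)cc12` gives 5.14 h.

Among these three, compound 2 shows the highest number in this assay. Compound 3 lies within the usual scatter of compound 2, so no order can be read between them, while compound 1 lies clearly below. For the measured compounds named here, only one measured step changes a single place on the shared core: a 4.6-fold higher number from compound 1 to compound 2 (0.66 log units; beyond the scatter). That step shows that the aryl group at this position can move the half-life by a modest but real amount.

Compound 4 `CC(c1ccc(Cl)c(F)c1)N1CC2(CCN(c3nc(=O)c4cc(C(F)(F)F)cc([N+](=O)[O-])c4s3)CC2)C1` has not yet been measured. It differs from compound 2 as follows: 4-chloro-3-fluorophenyl in place of 4-(trifluoromethoxy)phenyl on a saturated chain carbon bound to an amine nitrogen in a ring and a saturated chain carbon. Going by the values given here, since the only comparable step, from compound 1 to compound 2, was of modest size and 4-chloro-3-fluorophenyl is a halogenated ring like the 3,4,5-trifluorophenyl of compound 1, a decrease is expected for compound 4, of size a 2.1-fold lower number from compound 2 to compound 4 (0.33 log units; beyond the scatter), though smaller than the full return to compound 1. The estimated half-life of compound 4 in this assay is 4 h, with a range from 1.8 h to 9 h.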

Compound 4, half-life: 7.5 h
Beside the measured number, compound 4's estimate is 1.9-fold (0.27 log units) below it; measured number inside the range.
By their numbers in this assay, from the lowest: compound 1; then compounds 3, 4 and 2 (each within the scatter of the next).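

In this assay, 4-chloro-3-fluorophenyl in place of 4-(trifluoromethoxy)phenyl gives a 1.1-fold lower number from compound 2 to compound 4 (0.05 log units; within the scatter) and so leaves the half-life unchanged within normal variation: at this position, two rings with quite different substituents cannot be told apart. The other new comparison, with 4-chloro-3-fluorophenyl in place of 3,4,5-trifluorophenyl, gives a 4.0-fold higher number from compound 1 to compound 4 (0.61 log units; beyond the scatter) and shows that carrying halogens on the ring does not by itself bring the short half-life of compound 1, which stays alone at the low end among these aryl compounds. Nothing available here explains why compound 1 differs from compound 2 and compound 4.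

Still open, on these data alone, is whether the aryl ring is needed at all. It is also unknown how the half-life would respond at this place to a ring carrying a nitrile, a methoxy group or a carboxylic acid.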